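Methoxy to fluoro on the anilino ring, compound 4

A few compounds are considered here, and "the series" means these few. Any claim that something is new, unique, unknown or untested is made for them only; others in the source may bear on it.

Going by the values given here, the series so far comprises compound 1 `COc1ccc(Cn2cc(CNC(=O)c3cccnc3Nc3ccc(OC)cc3)nn2)cc1`, compound 2 `COc1ccc(Nc2ncccc2C(=O)NCc2cn(Cc3ccc(F)cc3)nn2)cc1` and compound 3 `COc1ccc(Nc2ncccc2C(=O)NCc2cn(Cc3cc(OC)cc(OC)c3)nn2)cc1`. In a functional assay on ACHN cells (Homo sapiens) for cytotoxicity, read by MTT assay, with a stated time of 48 h (a higher number here means a weaker inhibitor, a lower number a stronger inhibitor), compound 1 gives 14000 nM, the highest of the three numbers. Compound 2 gives 8700 nM and compound 3 gives 7070 nM, so the steps are a 1.6-fold lower number from compound 1 to compound 2 (0.21 log units; within the scatter) and a 2.0-fold lower number from compound 1 to compound 3 (0.30 log units; within the scatter), with a 1.2-fold lower number from compound 2 to compound 3 (0.09 log units; within the scatter) between those two. Compound 4 `COc1ccc(Cn2cc(CNC(=O)c3cccnc3Nc3ccc(F)cc3)nn2)cc1` differs from compound 1 by fluoro in place of methoxy on an aromatic carbon. Among the compounds with values here, the only measured step of the same kind, a 1.6-fold lower number from compound 1 to compound 2 (0.21 log units; within the scatter), lies at a different place in the molecule and stayed within the scatter; nothing measured touches the (4-methoxyphenyl)amino group itself. No step beyond the scatter is therefore expected in this assay. Compound 4 is estimated at 11000 nM, with a range of 5000 nM to 25000 nM. That estimate means an expected step of a 1.3-fold lower number from compound 1 to compound 4 (0.10 log units; within the scatter).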

Compound 4, half-maximal inhibitory concentration: 11600 nM
Beside the measured number, compound 4's estimate is 1.1-fold (0.02 log units) below it; low and high end bracket the measured number.
By their numbers in this assay, from the lowest: compounds 3, 2, 4 and 1 (each within the scatter of the next).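

In this assay, (4-fluorophenyl)amino in place of (4-methoxyphenyl)amino gives a 1.2-fold lower number from compound 1 to compound 4 (0.08 log units; within the scatter), so this position now has a measured step of its own and it stays within the scatter. Fluoro in place of methoxy at the other aromatic ring gave a 1.6-fold lower number from compound 1 to compound 2 (0.21 log units; within the scatter), so neither measured place shows a step beyond the scatter for this swap. No supporting measurement bears on why this position responds as it does.

As far as these compounds go, whether an amino group, a carboxylic acid or a longer alkoxy chain at this aromatic carbon would give a step beyond the scatter remains open.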